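Amide variation on a shared core: a chloro addition

The compounds below may be only part of what the source reports. "The series", "measured", "known", "first", "only" and "open" are said of these compounds alone.

Three amides on the shared core have been measured in a functional assay on MDA-MB-231 cells (Homo sapiens) for antiproliferative activity, read by MTT assay, with stated times of 72 h and 4 h; on this read-out higher numbers stand for weaker inhibition and lower numbers for stronger inhibition. Compound 1 `O=C(Nc1ccc(Cl)c(-c2nnc3c(Cl)cccn23)c1)c1ccc(F)cc1Cl` gives 75000 nM in this assay. Compound 2 `O=C(Nc1ccc(Cl)c(-c2nnc3c(Cl)cccn23)c1)c1ccccn1` gives 92000 nM in this assay, a change of a 1.2-fold higher number from compound 1 to compound 2 (0.09 log units; within the scatter). Compound 3 `O=C(Nc1ccc(Cl)c(-c2nnc3c(Cl)cccn23)c1)c1ccc(Cl)cc1` reaches only the limit of this assay, > 100000 nM, so for compound 3 no number is known, only (the limit of > 100000 nM in this assay, at which 1 of the 3 values shown sits). The step of an at least 1.3-fold higher number from compound 1 to compound 3 (0.12 log units; that floor lies within the scatter) and the step of an at least 1.0-fold higher number from compound 2 to compound 3 (0.03 log units; that floor lies within the scatter) are therefore floors, and neither floor leaves the scatter.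

Compound 4 `O=C(Nc1ccc(Cl)c(-c2nnc3c(Cl)cccn23)c1)c1ccc(Cl)cc1Cl` has not yet been measured. It differs from compound 3 by chloro in place of hydrogen on an aromatic carbon, a chloro entering on an aromatic carbon of a six-membered aromatic ring of carbon only, ortho to a large group and meta to a chloro group; read one bond further out, 4-chlorophenyl becomes 2,4-dichlorophenyl. The nearest measured step, an at least 1.3-fold higher number from compound 1 to compound 3 (0.12 log units; that floor lies within the scatter), removed a chloro from that same kind of position together with a fluoro-to-chloro exchange and stayed within the scatter. No step beyond the scatter is expected in this assay; the expected step from compound 3 to compound 4 is an at least 1.1-fold lower number from compound 3 to compound 4 (0.04 log units; that floor lies within the scatter). Compound 4 is estimated at 90000 nM, with a range from 45000 nM to 180000 nM, and a limit value is a plausible outcome for compound 4 as well.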

Compound 4, half-maximal inhibitory concentration: > 100000 nM
Compound 4: no number, only a limit; the forecaster's own chance of this, stated with the estimate: 50%; middle value at least 1.1-fold (0.04 log units) from the limit.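

In this assay, compound 3 and compound 4 both stand at a limit, so adding a chloro to 4-chlorophenyl gives a step that cannot be read, and the 2,4-dichlorophenyl amide gives no measured number: the limit of > 100000 nM in this assay, at which 2 of the 4 values shown sit.

Chloro in place of fluoro on an aromatic carbon gives an at least 1.3-fold higher number from compound 1 to compound 4 (0.12 log units; that floor lies within the scatter), a change in one place that the earlier compounds did not offer, and it shows no step beyond the scatter. 2,4-Dichlorophenyl in place of pyridin-2-yl gives an at least 1.0-fold higher number from compound 2 to compound 4 (0.03 log units; that floor lies within the scatter), again with a floor that does not leave the scatter.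

The compounds shown leave open whether any group at the place of the new chloro can move the value beyond the scatter, for example an amine, a carboxylic acid or a methoxy group. With two of the four compounds at a limit, they also leave open how far compound 3 and compound 4 lie from compound 1 and compound 2, and whether the two limit compounds differ from each other at all.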